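Swapping a Thiazole for Phenyl: Expected Effect on Lipophilicity

This account rests on a few compounds, and the source may have more. Where it says the series, first, only, none or still open, it means among the compounds named here.

Compound 1 `CCNC(=O)Nc1cc(Br)c(-c2cncc(C(=O)O)c2)cn1`: -1
Compound 2 `CCNC(=O)Nc1cc(-c2nc(C(C)(C)C)cs2)c(-c2cncc(C(=O)O)c2)cn1`: 0.12
Compound 3 `CCNC(=O)Nc1cc(-c2nc(C(F)(F)F)cs2)c(-c2cncc(C(N)=O)c2)cn1`: 2

In a physicochemical assay for lipophilicity, using the shake flask method, in phosphate buffer, measured as octanol-water partition, with a stated time of 1 h, at pH 7.4 (on this read-out lower numbers stand for lower lipophilicity and higher numbers for higher lipophilicity), compound 2 stands second highest of the three, with compound 1 nearest and compound 3, which differs in two places, furthest. Compound 4 `CCNC(=O)Nc1cc(-c2ccccc2)c(-c2cncc(C(=O)O)c2)cn1` is not yet measured. Its change from compound 2 is phenyl in place of 4-(tert-butyl)-1,3-thiazol-2-yl on an aromatic carbon. Going by the values given here, the only measured step at this position, a number 1.12 log units higher from compound 1 to compound 2 (beyond the scatter), shows how strongly this site moves the read-out. Phenyl carries fewer heavy atoms than the group it replaces and no tert-butyl, so a downward step is expected, smaller than that one. For compound 4 the expected change is a number 0.62 log units lower from compound 2 to compound 4 (beyond the scatter), giving an estimate of -0.5 with a range from -1.2 to 0.3.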

Compound 4, distribution coefficient: -0.31
Beside the measured number, compound 4's estimate is 0.19 log units below it; measured number inside the range.
By their numbers in this assay, from the lowest: compound 1; then compound 4; then compound 2; then compound 3.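

In this assay, phenyl in place of the thiazole gives a number 0.43 log units lower from compound 2 to compound 4 (beyond the scatter), and phenyl in place of bromo gives a number 0.69 log units higher from compound 1 to compound 4 (beyond the scatter). At this position on the shared core, the order from the lowest number is now bromo, phenyl, then 4-(tert-butyl)-1,3-thiazol-2-yl, with phenyl clearly apart from both. No measurement shown gives a reason for this order. Still open, going by these compounds, is how a phenyl carrying an amine or a methoxy group would read here. Also open, on these data alone, is whether the same order holds when the carboxylic acid is replaced by an amide.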